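Adding a Methoxy Group: What Compound 4 May Show

The source may hold more compounds than are shown below. What is called first, only, known or untested is meant among the compounds shown, and "the series" means these compounds.

Measured compounds, with values from a functional assay on HepG2 cells (Homo sapiens) for inhibition, read by MTT assay, with a stated time of 72 h; on this read-out higher numbers stand for weaker inhibition and lower numbers for stronger inhibition:

compound 1, `COc1ccc(/C=C/C(=O)c2c(O)cc(O)cc2OC)cc1`, gives 18100 nM
compound 2, `COc1ccc(/C=C/C(=O)c2c(O)cc(O)cc2OC)cc1OC`, gives 18500 nM
compound 3, `COc1cc(/C=C/C(=O)c2c(OC)cc(OC)cc2OC)cc(OC)c1`, gives 9000 nM

Compound 1 and compound 2 share a core and differ by one change, (methoxy in place of hydrogen on an aromatic carbon), which gave a 1.0-fold higher number from compound 1 to compound 2 (0.01 log units; within the scatter). Compound 3 has a different core; how it differs from compound 1 is not broken down here. Against the other two, compound 3 shows the lowest number, and its gap to compound 2 is beyond the scatter.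

Compound 4, `COc1cc(OC)c(C(=O)/C=C/c2cc(OC)c(OC)c(OC)c2)c(OC)c1`, has not yet been measured in this assay. It arises from compound 3 by methoxy in place of hydrogen on an aromatic carbon. Among the compounds with values here, this is the same kind of change as the one from compound 1 to compound 2, but not the same: there the entering methoxy sat ortho to a methoxy group and meta to a large group, whereas here it sits ortho to two methoxy groups and para to a large group. Because the earlier step of a 1.0-fold higher number from compound 1 to compound 2 (0.01 log units; within the scatter) lay within the scatter, the step from compound 3 to compound 4 is expected to be about no change at the digits printed from compound 3 to compound 4 (within the scatter). Compound 4 is therefore estimated at 9000 nM, with a range from 4500 nM to 18000 nM.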

Compound 4, half-maximal inhibitory concentration: 16500 nM
For compound 4 the middle estimate is 1.8-fold (0.26 log units) below the measured one; low and high end bracket the measured number.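

In this assay, methoxy in place of hydrogen on an aromatic carbon gave a 1.8-fold higher number from compound 3 to compound 4 (0.26 log units; within the scatter). Set beside the earlier step, the change carries from one core to the other with no difference that can be told from the scatter: the same change on two cores in this assay, a 1.0-fold higher number (0.01 log units; within the scatter) from compound 1 to compound 2 and a 1.8-fold higher number (0.26 log units; within the scatter) from compound 3 to compound 4, 1.8-fold (0.25 log units) apart, within the scatter of two such steps. Within the data shown here, this shows only that the step stayed within the scatter on both cores; it does not show that the change would do the same on any further core, and with a single pair on each core, the effect of the core cannot be told apart from that of the place where the methoxy group enters.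

The compounds shown carry only hydroxy and methoxy groups on their aromatic rings, and what an amine, a carboxylic acid or a fluorine at the same place would do stays open. Also open, from the compounds shown here alone, is whether a longer chain, such as ethoxy, would give steps like those of methoxy on these two cores.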